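The source may hold more compounds than are shown below. What is called first, only, known or untested is meant among the compounds shown, and "the series" means these compounds.

Measured so far:
compound 1 `Clc1ccc2[nH]c(-c3cn(-c4ccccc4)nc3-c3ccccc3)nc2c1`: 2370 nM
compound 2 `COc1ccc2[nH]c(-c3cn(-c4ccccc4)nc3-c3ccccc3)nc2c1`: 1230 nM
Not yet measured:
compound 3 `Clc1cc2nc(-c3cn(-c4ccccc4)nc3-c3ccccc3)[nH]c2cc1Cl`

In a functional assay on A549 cells (Homo sapiens) for antiproliferative activity, read by MTT assay, with a stated time of 48 h (a higher number here means a weaker inhibitor, a lower number a stronger inhibitor), compound 1 gives 2370 nM, which stands within the scatter of compound 2. Compound 3 puts chloro in place of hydrogen on an aromatic carbon, ortho to a chloro group (chloro in place of hydrogen on an aromatic carbon). Among the compounds with values here, only one measured step bears on this change, and only loosely, since it swaps a group on the same core: a 1.9-fold lower number from compound 1 to compound 2 (0.28 log units; within the scatter). That step is small, so no shift beyond the scatter is expected here, in either direction. The expected step is a 1.2-fold lower number from compound 1 to compound 3 (0.07 log units; within the scatter). For compound 3 the estimated value is 2000 nM, with an expected range of 800 nM to 5000 nM.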

Compound 3, half-maximal inhibitory concentration: 11100 nM
The estimate for compound 3 lay 5.6-fold (0.74 log units) below the measured number; measured number above the stated range.
By their numbers in this assay, from the lowest: compounds 2 and 1 (each within the scatter of the next); then compound 3.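

In this assay adding chloro on an aromatic carbon ortho to the existing chloro group gives a 4.7-fold higher number from compound 1 to compound 3 (0.67 log units; beyond the scatter) and so weakens the compound beyond the scatter. The earlier step, which replaced that existing chloro group with methoxy, stayed within the scatter, so this is the first change shown that clearly moves the number. Nothing available explains this loss. As far as these compounds go, whether a fluoro or an amino group on this same carbon would also raise the number remains open, as does whether chloro here would do so without the first chloro group.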